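A few compounds are considered here, and "the series" means these few. Any claim that something is new, unique, unknown or untested is made for them only; others in the source may bear on it.

Of the compounds shown here, three sharing one core have been tested in a functional assay for inhibition of nuclear factor NF-kappa-B complex (Homo sapiens); a higher number here means a weaker inhibitor, a lower number a stronger inhibitor. Compound 1 `COc1ccc2c(c1)OC(c1cc(OC)c(OC)c(OC)c1)C(C(C)=O)=C2` gives 14100 nM, compound 2 `COc1ccc2c(c1)OC(c1cc(OC)c(OC)c(OC)c1)C(C=O)=C2` gives 13500 nM, and compound 3 `COc1ccc2c(c1)OC(c1cc(OC)c(OC)c(OC)c1)C(C(=O)Nc1ccccc1)=C2` gives 17500 nM. Compound 3 has the highest of the three numbers, yet its gaps to the other two are small: a 1.2-fold higher number from compound 1 to compound 3 (0.09 log units; within the scatter) and a 1.3-fold higher number from compound 2 to compound 3 (0.11 log units; within the scatter), so the three read as indistinguishable on this assay.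

Compound 4 `COc1ccc2c(c1)OC(c1cc(OC)c(OC)c(OC)c1)C(C(=O)NC(C)C)=C2` is the next step from compound 3, with isopropyl in place of phenyl on an amide-type nitrogen. The measured steps that come closest are the ones that reshaped the group on the carbonyl carbon, a 1.2-fold higher number from compound 1 to compound 3 (0.09 log units; within the scatter) and a 1.3-fold higher number from compound 2 to compound 3 (0.11 log units; within the scatter), and also a 1.0-fold lower number from compound 1 to compound 2 (0.02 log units; within the scatter); all of them stayed within the scatter, suggesting this assay has so far been indifferent to what hangs on that carbonyl. None of them swaps phenyl for isopropyl on an amide-type nitrogen, so the evidence is indirect. Compound 4 is therefore expected to show no step beyond the scatter, with a 1.1-fold lower number from compound 3 to compound 4 (0.04 log units; within the scatter). The estimate for compound 4 is 16000 nM, within a range from 8000 nM to 32000 nM.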

Compound 4, half-maximal inhibitory concentration: > 50000 nM
Compound 4 was reported as a limit; the forecaster's own chance of this, stated with the estimate: 10%; middle value at least 3.1-fold (0.49 log units) from the limit.
By their numbers in this assay, from the lowest: compounds 2, 1 and 3 (each within the scatter of the next). At a limit, above all of these: compound 4.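

Within the data shown here, until now, what hung on the carbonyl seemed not to matter in this assay, yet isopropyl in place of phenyl on the amide-type nitrogen gives an at least 2.8-fold higher number from compound 3 to compound 4 (0.45 log units; beyond the scatter), the first step here beyond the scatter. Compound 4 also separates from the two compounds without an amide, with an at least 3.7-fold higher number from compound 2 to compound 4 (0.56 log units; beyond the scatter) and an at least 3.5-fold higher number from compound 1 to compound 4 (0.54 log units; beyond the scatter), so the amide alone does not explain the change: compound 3 is also an amide, yet it stays within the scatter of both, and what sits on that nitrogen decides the outcome. The value for compound 4 is a limit, not a number: the limit of > 50000 nM in this assay, at which 1 of the 4 values shown sits.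

The compounds shown cannot tell whether an aromatic ring is needed on that nitrogen or any ring would do, and a cyclohexyl group there would separate those two readings. On these data alone, how far compound 4 lies past its limit also stays open.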